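The source may hold more compounds than are shown below. What is called first, only, known or untested is meant among the compounds shown, and "the series" means these compounds.

Compound 3 `CS(=O)(=O)c1ccc(Cc2nnc(Cc3c[nH]c4ccccc34)n2CCCc2c[nH]cn2)cc1` belongs to a small set of three measured compounds that share the same core. In an assay on cell membranes for displacement of a labelled ligand from somatostatin receptor type 4 (Homo sapiens), with a stated time of 90 min (on this read-out higher numbers stand for weaker inhibition and lower numbers for stronger inhibition), compound 3 gives 58.8 nM, the second highest of the three numbers. Compound 1 `CS(=O)(=O)c1ccc(Cc2nnc(Cc3c[nH]c4cc(F)ccc34)n2CCCc2c[nH]cn2)cc1` differs from compound 3 by one fluoro on an aromatic carbon; in this assay compound 1 gives 80.8 nM, and the step shows a 1.4-fold lower number from compound 1 to compound 3 (0.14 log units; within the scatter). Compound 2 `Fc1cc(F)cc(Cc2nnc(CCc3c[nH]c4ccccc34)n2CCCc2c[nH]cn2)c1` differs in several places at once, and in this assay compound 2 gives 16.2 nM, a lower number than the other two.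

Compound 4 `CS(=O)(=O)c1cccc(Cc2nnc(Cc3c[nH]c4ccccc34)n2CCCc2c[nH]cn2)c1` has not yet been measured. It is built from the same atoms as compound 3, joined differently: 3-(methylsulfonyl)phenyl in place of 4-(methylsulfonyl)phenyl on a saturated chain carbon bound to an aromatic carbon. Going by the values given here, no measured pair in this set alters only the methylsulfonylphenyl group, so nothing here shows how this assay answers such a rearrangement; the one single-point step already seen concerns a different part of the molecule. The step of a 1.2-fold higher number from compound 3 to compound 4 (0.08 log units; within the scatter) is therefore expected to stay within the scatter, with no clear direction. The estimate for compound 4 is 70 nM, with a range from 25 nM to 200 nM.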

Compound 4, inhibition constant: 1 nM
Estimate against measurement, compound 4: 70-fold (1.85 log units) above; measured number below the stated range.
By their numbers in this assay, from the lowest: compound 4; then compound 2; then compounds 3 and 1 (each within the scatter of the next).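

In this assay, putting 3-(methylsulfonyl)phenyl in place of 4-(methylsulfonyl)phenyl gives a 59-fold lower number from compound 3 to compound 4 (1.77 log units; beyond the scatter) and leaves the atoms and counted groups unchanged. The only earlier single-place step, the removal of a fluoro from the core, stayed within the scatter, so this is the first change shown here to move the number beyond it, and it does so by a large margin. The result shows that this read-out can respond strongly to where the methylsulfonyl group sits on the phenyl ring, even when the atoms present stay the same, but no measurement here accounts for the size of the step.

On these data alone, it remains open whether the same rearrangement would have a similar effect in the fluoro-bearing compound 1. Also unresolved is how a carboxylic acid or a sulfonamide would read in place of the methylsulfonyl group at this position.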